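Working notes: plasma stability across two ester positions

This account rests on a few compounds, and the source may have more. Where it says the series, first, only, none or still open, it means among the compounds named here.

Measured so far:
compound 1, `C[C@@H](O)[C@H]1C(=O)N2C(C(=O)OCOC(=O)C(C)(C)C)=C(S[C@@H]3CN[C@H](C(=O)Nc4cccc(C(=O)O)c4)C3)[C@H](C)[C@H]12`: 45%
compound 2, `C[C@@H](O)[C@H]1C(=O)N2C(C(=O)OCC(F)(F)F)=C(S[C@@H]3CN[C@H](C(=O)Nc4cccc(C(=O)O)c4)C3)[C@H](C)[C@H]12`: 80%
compound 3, `C[C@@H](O)[C@H]1C(=O)N2C(C(=O)O)=C(S[C@@H]3CN[C@H](C(=O)Nc4cccc(C(=O)OCC(F)(F)F)c4)C3)[C@H](C)[C@H]12`: "not determined" (no result reported)

In an ADME assay on a cell-free system (plasma, Homo sapiens) for metabolic stability, read by LC-MS, with a stated time of 60 min, at 37 degrees C, tested at 50 uM (on this read-out lower numbers stand for a less stable compound and higher numbers for a more stable compound), compound 2 gives 80%, while compound 1 gives 45%. The two differ only by the change (((tert-butyl)carbonyl)oxy in place of trifluoromethyl on a saturated chain carbon bound to an oxygen next to a carbonyl group), and that change made a step of a number 35 percentage points lower from compound 2 to compound 1 (beyond the scatter) in this assay.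

Compound 3 carries its esterified carboxyl on the other side of the molecule; how the core of compound 3 differs from the core of compound 2 is not broken down here, and in this assay compound 3 has "not determined" (no result reported).

Compound 4, `C[C@@H](O)[C@H]1C(=O)N2C(C(=O)O)=C(S[C@@H]3CN[C@H](C(=O)Nc4cccc(C(=O)OCOC(=O)C(C)(C)C)c4)C3)[C@H](C)[C@H]12`, is not yet measured. It stands to compound 3 as compound 1 stands to compound 2: the change (((tert-butyl)carbonyl)oxy in place of trifluoromethyl on a saturated chain carbon bound to an oxygen next to a carbonyl group), at the same kind of position as written for the measured pair, so this is the same change seen once more. With no value for compound 3, nothing anchors the new pair. What can be taken over is the direction and size of the earlier step, a number 35 percentage points lower from compound 2 to compound 1 (beyond the scatter), which points toward lower remaining compound once the entering group is in place. Going by the values given here, on that basis compound 4 is expected to land near 40% in this assay, with an estimated range of 15% to 70%, the width reflecting that only one measured pair supports the expectation.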

Compound 4, percent of the compound remaining: 53%
Estimate against measurement, compound 4: 13 percentage points below; the measured number falls inside the stated range.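

In this assay, going by these compounds alone, compound 4 gives 53% but compound 3 has no single number, so no step from compound 3 to compound 4 can be read. The compounds shown leave open whether the same change, between compound 3 and compound 4, repeats a number 35 percentage points lower from compound 2 to compound 1 (beyond the scatter). Nothing shown bears on the reason for these values.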